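The source may hold more compounds than are shown below. What is called first, only, known or untested is meant among the compounds shown, and "the series" means these compounds.

Compound 1 `Cc1cccc(C)c1-c1cccc(COc2ccc(CCC(=O)O)s2)c1` and compound 2 `CC#CC(CC(=O)O)c1ccc(OCc2cccc(-c3c(C)cccc3C)c2)s1` share one core. In a functional assay on cells for agonist activity at Free fatty acid receptor 1 (Homo sapiens), read by calcium flux (a lower number here means that less compound is needed, a higher number that more compound is needed for the effect), compound 1 gives 32 nM, and compound 2 gives 210 nM, the higher of the two numbers. For the measured compounds named here, the only measured step, a 6.6-fold higher number from compound 1 to compound 2 (0.82 log units; beyond the scatter), put prop-1-yn-1-yl on a saturated chain carbon bound to an aromatic carbon and a saturated chain carbon. Compound 3 `CCOC(CC(=O)O)c1ccc(OCc2cccc(-c3c(C)cccc3C)c2)s1` differs from compound 2 by ethoxy in place of prop-1-yn-1-yl on a saturated chain carbon bound to an aromatic carbon and a saturated chain carbon. Going by the values given here, no measured step swaps one such group for another, so the direction is uncertain; the expected step is a 1.4-fold lower number from compound 2 to compound 3 (0.15 log units; within the scatter). Compound 3 is therefore estimated at 150 nM, within 50 nM to 600 nM.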

Compound 3, half-maximal effective concentration: 57 nM
Compound 3: the middle estimate sits 2.6-fold (0.42 log units) above what was measured, and the stated range covers the measured number.
By their numbers in this assay, from the lowest: compounds 1 and 3 (each within the scatter of the next); then compound 2.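

In this assay, the group on the saturated chain carbon bound to an aromatic carbon and a saturated chain carbon matters beyond its heavy-atom count: ethoxy in place of prop-1-yn-1-yl gives a 3.7-fold lower number from compound 2 to compound 3 (0.57 log units; beyond the scatter), although both groups count the same. Substitution at this carbon therefore need not carry a measurable penalty, as ethoxy in place of hydrogen gives a 1.8-fold higher number from compound 1 to compound 3 (0.25 log units; within the scatter) and stays within the scatter. No measurement here bears on why ethoxy and prop-1-yn-1-yl differ. The compounds shown leave open how a hydroxyl, a methoxy or a longer alkoxy chain on this carbon would read.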